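The compounds below may be only part of what the source reports. "The series", "measured", "known", "first", "only" and "open" are said of these compounds alone.

Measured so far:
compound 1, `O=C(NO)c1ccc(-c2cn([C@H]3C[C@H](CO)N(CCCc4ccccc4)C3)nn2)cc1`, 18%
compound 2, `O=C(/C=C/c1cn([C@H]2C[C@H](CO)N(Cc3ccccc3)C2)nn1)NO`, 20%

In an assay on Sf9 cells for inhibition of histone deacetylase 11 (Homo sapiens), read by fluorescence, tested at 0.5 uM (on this read-out higher numbers stand for more inhibition at the one concentration tested (going by the name of the read-out) and lower numbers for less inhibition), compound 2 gives 20%, and compound 1 gives 18%: the two numbers lie within the scatter of each other, so neither inhibition in this assay can be called higher or lower. Among the measured compounds shown here, no step between these two is laid out, since they differ in more than one place.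

Compound 3, `O=C(/C=C/c1cn([C@H]2C[C@H](CO)N(CCCc3ccccc3)C2)nn1)NO`, has not yet been measured in this assay. It differs from compound 2 in one place: phenethyl in place of phenyl on a saturated chain carbon bound to an amine nitrogen in a ring. For the measured compounds named here, the data hold no measured step of this kind. Compound 1, which carries the 3-phenylpropyl group on the same ring nitrogen, gives 18% in this assay, so no step beyond the scatter is expected from compound 2 to compound 3, with the estimated step being a number 1 percentage points lower from compound 2 to compound 3 (within the scatter). Compound 3 is estimated at 19%, in a range from 5% to 35%.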

Compound 3, a percentage reported as inhibition, at one concentration (the size of the read-out at that concentration, not a potency): 16%
Compound 3: the middle estimate sits 3 percentage points above what was measured, and the stated range covers the measured number.
By their numbers in this assay, from the lowest: compounds 3, 1 and 2 (each within the scatter of the next).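

In this assay, phenethyl in place of phenyl on a saturated chain carbon bound to an amine nitrogen in a ring, the same difference as benzyl to 3-phenylpropyl, gives a number 4 percentage points lower from compound 2 to compound 3 (within the scatter), so this position now has a measured step and it does not separate the two chain lengths. With 3-phenylpropyl held fixed, 2-(hydroxycarbamoyl)ethenyl in place of 4-(hydroxycarbamoyl)phenyl on an aromatic carbon gives a number 2 percentage points lower from compound 1 to compound 3 (within the scatter), which does not separate those two groups either. No evidence on hand bears on these two steps.

On these data alone, whether a longer chain than 3-phenylpropyl, or an amine or a carboxylic acid in place of the terminal phenyl, would give a step beyond the scatter remains open. With a single concentration, the potency of these compounds also remains open.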